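The compounds below may be only part of what the source reports. "The series", "measured", "known", "first", "only" and "open" are said of these compounds alone.

In a functional assay on MDA-MB-231 cells (Homo sapiens) for antiproliferative activity, read by MTT assay, with a stated time of 24 h (on this read-out lower numbers stand for stronger inhibition and higher numbers for weaker inhibition), compound 1 `O=C(NNc1ccccc1Cl)c1ccc(NS(=O)(=O)c2cnc(O)nc2O)cc1` gives 4010 nM and compound 2 `O=C(NNC(=O)c1ccccc1Cl)c1ccc(NS(=O)(=O)c2cnc(O)nc2O)cc1` gives 13900 nM, so compound 2 holds the higher, weaker number of the two. Compound 3 `O=C(NNC(=O)c1ccc(NS(=O)(=O)c2cnc(O)nc2O)cc1)c1ccc(F)cc1` differs from compound 2 as follows: 4-fluorophenyl in place of 2-chlorophenyl on a carbonyl carbon. Within the data shown here, the only measured step, a 3.5-fold higher number from compound 1 to compound 2 (0.54 log units; beyond the scatter), is modest and concerns a different change, so it bears only loosely on this one. Among the measured compounds shown here, no measured compound carries 4-fluorophenyl, so only a small expected step stands here, a 1.4-fold lower number from compound 2 to compound 3 (0.14 log units; within the scatter), within the scatter. Compound 3 is estimated at 10000 nM, with an expected range of 4000 nM to 25000 nM.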

Compound 3, half-maximal inhibitory concentration: > 20000 nM
Compound 3: no number, only a limit; the forecaster's own chance of this, stated with the estimate: 5%; middle value at least 2.0-fold (0.30 log units) from the limit.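

In this assay compound 3 gives only a limit, > 20000 nM, not a number. Replacing 2-chlorophenyl with 4-fluorophenyl on the carbonyl carbon gives an at least 1.4-fold higher number from compound 2 to compound 3 (0.15 log units; that floor lies within the scatter), so this change cannot yet be sized at this place. The wider change on the amine nitrogen gives an at least 4.9-fold higher number from compound 1 to compound 3 (0.69 log units; beyond the scatter), which runs in the same direction as a 3.5-fold higher number from compound 1 to compound 2 (0.54 log units; beyond the scatter).

From the compounds shown here alone, how far the true value of compound 3 lies past its limit stays open. So does what a plain phenyl or a 4-methoxyphenyl on that carbonyl carbon would give.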